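Iodo for bromo on the phenoxy ring of compound 3

The compounds below may be only part of what the source reports. "The series", "measured", "known", "first", "only" and "open" are said of these compounds alone.

Compound 3 `N[C@@H](COP(=O)(O)OCCCOC(=O)CCc1ccccc1OCc1cccc(Oc2ccc(Br)cc2)c1)C(=O)O` gives 0.97 in an assay on cells for activation of probable G-protein coupled receptor 34 (Mus musculus), with a stated time of 1 h (a higher number here means a larger maximal response, a lower number a smaller maximal response), the highest of the three numbers. Compound 1 `N[C@@H](COP(=O)(O)OCCCOC(=O)CCc1ccccc1OCc1cccc(Oc2ccccc2)c1)C(=O)O` gives 0.48 and compound 2 `N[C@@H](COP(=O)(O)OCCCOC(=O)CCc1ccccc1OCc1cccc(Cc2ccccc2)c1)C(=O)O` gives 0.077; the steps a number 0.40 lower from compound 1 to compound 2 (beyond the scatter), a number 0.49 higher from compound 1 to compound 3 (beyond the scatter) and a number 0.89 higher from compound 2 to compound 3 (beyond the scatter) all lie beyond the scatter. Compound 4 `N[C@@H](COP(=O)(O)OCCCOC(=O)CCc1ccccc1OCc1cccc(Oc2ccc(I)cc2)c1)C(=O)O` differs from compound 3 by iodo in place of bromo on an aromatic carbon. Going by the values given here, no measured step swaps one halogen for another; the nearest is a number 0.49 higher from compound 1 to compound 3 (beyond the scatter), where bromo replaced hydrogen on an aromatic carbon. Compound 3 already sits near the top of the scale with 0.97, so only a small step is expected in this assay, probably none beyond the scatter. Compound 4 is therefore expected to give 0.95 (range 0.75 to 1.1), an estimated step of a number 0.020 lower from compound 3 to compound 4 (within the scatter).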

Compound 4, intrinsic activity: the largest response reached, as a fraction of the reference agonist's: 0.82
The estimate for compound 4 lay 0.13 above the measured number; the measured number falls inside the stated range.
By their numbers in this assay, from the lowest: compound 2; then compound 1; then compound 4; then compound 3.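

In this assay the identity of the halogen on this aromatic carbon, para to a large group, matters: iodo does not match bromo (a number 0.15 lower from compound 3 to compound 4 (beyond the scatter)). Iodo still keeps a clear gain over hydrogen (a number 0.34 higher from compound 1 to compound 4 (beyond the scatter)), and 4-iodophenoxy stands well clear of benzyl (a number 0.74 higher from compound 2 to compound 4 (beyond the scatter)), so the gain does not belong to bromo alone. Nothing available explains the gap between the two halogens.

Open, going by these compounds, is whether chloro or fluoro on this carbon would hold the response of compound 3. Also open, on these data alone, is how a nitrile or methoxy group would compare there.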